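A few compounds are considered here, and "the series" means these few. Any claim that something is new, unique, unknown or untested is made for them only; others in the source may bear on it.

Measured so far:
- compound 1, `CN(C(=O)NCCCOc1ccc2nc(O)ccc2c1)[C@@H]1CCCC[C@H]1O`: in a functional assay on the whole organism for inhibition, with Mus musculus as the target, at a dose of 30 mg/kg by the oral route (a higher number here means more inhibition at the dose given (going by the name of the read-out), a lower number less inhibition), compound 1 gives 18%
- compound 2, `O=C(NCCCOc1ccc2nc(O)ccc2c1)N(C1CCCCC1)[C@H]1CCCC[C@@H]1O`: compound 2 gives 57%
- compound 3, `CCN(CCCOc1ccc2nc(O)ccc2c1)C(=O)N(C)C1CCCCC1`: compound 3 gives 58%

Compound 2 stands second highest of the three numbers. Its nearest neighbour is compound 3, whose number lies within the scatter of it, so no order between compound 2 and compound 3 is claimed. Its furthest is compound 1, whose number lies beyond the scatter below it.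

The unmeasured compound is compound 4, `O=C(NCCCOc1ccc2nc(O)ccc2c1)N(C1CC1)[C@H]1CCCC[C@@H]1O`. It differs from compound 2 in one place: cyclopropyl in place of cyclohexyl on an amide-type nitrogen. Among the measured compounds shown here, no step between measured compounds isolates this change, so its direction is not known from the series. Compound 1 carries a methyl on the same amide-type nitrogen and gives 18%, so a smaller group there goes with a lower number in one case; cyclopropyl is intermediate in size between methyl and cyclohexyl.

A step downward of moderate size is expected in this assay, possibly beyond the scatter, as a number 17 percentage points lower from compound 2 to compound 4 (beyond the scatter). For compound 4 the estimate is 40%, with a range from 15% to 65%.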

Compound 4, a percentage reported as inhibition, in the whole organism at one dose (the size of the read-out at that dose, not a potency): 100%
For compound 4 the middle estimate is 60 percentage points below the measured one, and the stated range ends below it.
By their numbers in this assay, from the lowest: compound 1; then compounds 2 and 3 (each within the scatter of the next); then compound 4.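

In this assay the group on this amide-type nitrogen proves a strong handle: with the rest of the structure unchanged, cyclopropyl in place of cyclohexyl gives a number 43 percentage points higher from compound 2 to compound 4 (beyond the scatter). The position is therefore not indifferent to the ring it carries, and in this single pair the smaller carbon ring goes with more inhibition at the dose given. Nothing available bears on the reason for this step.

On these data alone, whether cyclobutyl, cyclopentyl or an open chain such as isopropyl on the same nitrogen would give a number like that of compound 4 remains open. In this assay compound 4 gives 100% at a single dose, which is the size of the read-out and not a potency, so how far its margin over compound 2 would hold at lower doses is also unresolved.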